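Adding a 4-methylphenyl Group to the Ring Amide

This account rests on a few compounds, and the source may have more. Where it says the series, first, only, none or still open, it means among the compounds named here.

Three related compounds have been tested in a functional assay on HeLa cells (Homo sapiens) for antiproliferative activity, read by MTT assay, with a stated time of 72 h; a higher number here means a weaker inhibitor, a lower number a stronger inhibitor. Compound 2, `COc1ncc(-c2ccc3c(c2)NC(=O)CO3)cc1NS(=O)(=O)c1ccc(F)cc1`, gives 7110 nM. Compound 1, `COc1ncc(-c2ccc3c(c2)N(c2ccc(C)cc2)C(=O)CO3)cc1NS(=O)(=O)c1ccc(F)cc1`, differs from compound 2 by 4-methylphenyl in place of hydrogen on an amide-type nitrogen in a ring; in this assay compound 1 gives 4650 nM, and the step is a 1.5-fold lower number from compound 2 to compound 1 (0.18 log units; within the scatter). Compound 3, `O=C1COc2ccc(-c3cnc(Cl)c(NS(=O)(=O)c4ccc(F)cc4)c3)cc2N1`, differs from compound 2 in its core by chloro in place of methoxy on an aromatic carbon; in this assay compound 3 gives 15600 nM, the step being a 2.2-fold higher number from compound 2 to compound 3 (0.34 log units; beyond the scatter), and compound 3 stands with the highest number of the three.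

Compound 4, `Cc1ccc(N2C(=O)COc3ccc(-c4cnc(Cl)c(NS(=O)(=O)c5ccc(F)cc5)c4)cc32)cc1`, has not yet been measured. It differs from compound 3 by 4-methylphenyl in place of hydrogen on an amide-type nitrogen in a ring. Among the measured compounds shown here, this is the same change as the one between compound 2 and compound 1, since the two descriptions of the place agree word for word; only the cores differ, as set out in the difference between compound 2 and compound 3. Because the earlier step was a 1.5-fold lower number from compound 2 to compound 1 (0.18 log units; within the scatter), a small step within the scatter, the step from compound 3 to compound 4 is expected to be of similar size, a 1.4-fold lower number from compound 3 to compound 4 (0.15 log units; within the scatter). For the measured compounds named here, with only one earlier example, and that one within the scatter, the direction of the step is not secure. Compound 4 is therefore estimated at 11000 nM in this assay, with a plausible range from 4500 nM to 30000 nM.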

Compound 4, half-maximal inhibitory concentration: 32300 nM
Compound 4: the middle estimate sits 2.9-fold (0.47 log units) below what was measured; measured number above the stated range.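

In this assay, the 4-methylphenyl group in place of the amide hydrogen gives a 2.1-fold higher number from compound 3 to compound 4 (0.32 log units; beyond the scatter), so the effect of this change on the core of compound 2 does not carry over unaltered to the core of compound 3: the same change on two cores in this assay, a 1.5-fold lower number (0.18 log units; within the scatter) from compound 2 to compound 1 and a 2.1-fold higher number (0.32 log units; beyond the scatter) from compound 3 to compound 4, 3.2-fold (0.50 log units) apart, beyond the scatter of two such steps Seen from the other side, chloro in place of methoxy gives a 6.9-fold higher number from compound 1 to compound 4 (0.84 log units; beyond the scatter), a larger step than the same change makes without the 4-methylphenyl group: the same change on two cores in this assay, a 2.2-fold higher number (0.34 log units; beyond the scatter) from compound 2 to compound 3 and a 6.9-fold higher number (0.84 log units; beyond the scatter) from compound 1 to compound 4, 3.2-fold (0.50 log units) apart, beyond the scatter of two such steps Both comparisons rest on the same four compounds, so they are a single observation viewed in two ways: the two changes do not simply add up here, but this does not explain why, and it does not establish a true reversal of direction, since the step on the first core lies within the scatter.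

The compounds shown leave open whether a methyl or an unsubstituted phenyl group on the amide-type nitrogen in the ring would depend on the core in the same way. They also leave open how that nitrogen substitution would behave with an amine or a nitrile in place of the methoxy or chloro group.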